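This account rests on a few compounds, and the source may have more. Where it says the series, first, only, none or still open, it means among the compounds named here.

Working notes on a small set built on one shared core. Going by the values given here, in a functional assay on A549 cells (Homo sapiens) for inhibition, read by CCK-8 assay, with a stated time of 48 h (a lower number here means a stronger inhibitor, a higher number a weaker inhibitor), compound 2 `COc1cc(-c2ccnc3cc(-c4ccc(C(C)=O)cc4)nn23)cc(OC)c1OC` gives 4100 nM, which is the only number recorded in the set. Compound 1 `COc1cc(-c2ccnc3c(-c4ccc(C)cc4)cnn23)cc(OC)c1OC` reaches only the limit > 10000 nM in this assay. Compound 3 `Cc1ccc(-c2cc3nccc(-c4ccc(F)cc4)n3n2)cc1` likewise reaches only the limit > 10000 nM in this assay. Compound 2 therefore stands as the single quantified inhibitor, with nothing to rank it against, and the limit of > 10000 nM in this assay, at which 2 of the 3 values shown sit, marks the ceiling at which the rest of the set sits. Among the compounds with values here, no two measured compounds differ in one place only, so no measured step exists to lean on.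

Compound 4 `COc1ccc(-c2cc3nccc(-c4cc(OC)c(OC)c(OC)c4)n3n2)cc1` has yet to be measured in this assay. It differs from compound 2 by methoxy in place of acetyl on an aromatic carbon. With the methyl- and fluoro-bearing analogues both at the limit, the step from compound 2 to compound 4 is expected to be a loss beyond the scatter, estimated as a 2.0-fold higher number from compound 2 to compound 4 (0.29 log units; within the scatter). Compound 4 is estimated at 8000 nM, within a range from 3000 nM to 20000 nM, with a real chance that only a limit is returned.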

Compound 4, half-maximal inhibitory concentration: 376 nM
Estimate against measurement, compound 4: 21-fold (1.33 log units) above; measured number below the stated range.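

In this assay, going by these compounds alone, the change from 4-acetylphenyl to 4-methoxyphenyl gives the first measured step between compounds that differ in one place, and it reads an 11-fold lower number from compound 2 to compound 4 (1.04 log units; beyond the scatter). This shows that the group on this aromatic carbon, para to a large group, matters for the read-out: exchanging acetyl for methoxy alone, with the rest of the structure unchanged, moves the value well beyond the scatter. The other compounds still offer no step to set beside it, and the ceiling remains in the set: the limit of > 10000 nM in this assay, at which 2 of the 4 values shown sit.

Going by these compounds, with one step at this position, it remains open whether methoxy is special here or whether an amine, a hydroxyl or a longer ether such as ethoxy would serve as well. Within the data shown here, no second pair carries this same difference, so whether the step holds on other members is unknown.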